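The compounds below may be only part of what the source reports. "The series", "measured", "known", "first", "only" and "open" are said of these compounds alone.

Working notes on the series, all in a functional assay on HeLa cells (Homo sapiens) for inhibition, read by MTT assay; a lower number here means a stronger inhibitor, a higher number a weaker inhibitor. Compound 1 (`O=C(/C=C/c1cc(O)c(O)c([N+](=O)[O-])c1)OCCc1ccccc1`) is recorded as "not determined" (no result reported), and compound 3 (`O=C(/C=C/c1cc(O)c(O)c(Cl)c1)OCCc1ccccc1`) as "not determined" (no result reported). For the measured compounds named here, compound 2 (`CC1(C)C2CCC1(C)C(OC(=O)/C=C/c1cc(O)c(O)c(Br)c1)C2`) gives 22700 nM, the only number available, so it cannot yet be ranked against any other compound. Compound 4 (`CC1(C)C2CCC1(C)C(OC(=O)/C=C/c1cc(O)c(O)c(Cl)c1)C2`) remains to be measured and differs from compound 2 by chloro in place of bromo on an aromatic carbon, with chloro in place of bromo on an aromatic carbon. Going by the values given here, no measured pair shows this exchange, so nothing beyond the scatter is expected in this assay, in either direction. The estimated step of a 1.1-fold higher number from compound 2 to compound 4 (0.04 log units; within the scatter) is small. For compound 4 the expected value is 25000 nM, with an estimated range of 10000 nM to 60000 nM.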

Compound 4, half-maximal inhibitory concentration: 38700 nM
For compound 4 the middle estimate is 1.5-fold (0.19 log units) below the measured one; measured number inside the range.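

In this assay, for the compounds shown here, the exchange of chloro for bromo, on the aromatic carbon ortho to a hydroxy group, gives the only readable step: a 1.7-fold higher number from compound 2 to compound 4 (0.23 log units; within the scatter). With this shared core, the two halogens at this position cannot be told apart in this assay. No measurement on hand bears on this result.

On these data alone, it remains open whether an amine or a carboxylic acid at this position would give a step beyond the scatter. As far as these compounds go, whether the same exchange holds with an ester other than that of compound 2 also remains open.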